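A methyl added to the benzylidene ring of compound 3

The compounds below may be only part of what the source reports. "The series", "measured", "known", "first", "only" and "open" are said of these compounds alone.

Three glycosylated triazole compounds have been examined in a functional assay on HeLa cells (Homo sapiens) for cytotoxicity, read by sulforhodamine B assay, with a stated time of 48 h; on this read-out higher numbers stand for weaker inhibition and lower numbers for stronger inhibition. Compound 1 `COc1ccc2c(c1)c(C=O)cn2Cc1cn([C@@H]2O[C@H](COC(C)=O)[C@@H](OC(C)=O)[C@H](OC(C)=O)[C@H]2OC(C)=O)nn1` reaches only the limit of the assay, > 200000 nM. Compound 2 `CC(=O)OC[C@H]1O[C@@H](n2cc(Cn3cc(/C=C4/C(=O)Nc5ccc(F)cc54)c4ccccc43)nn2)[C@H](OC(C)=O)[C@@H](OC(C)=O)[C@@H]1OC(C)=O` likewise returns only a limit, > 200000 nM. Going by the values given here, compound 3 `CC(=O)OC[C@H]1O[C@@H](n2cc(CN3C(=O)/C(=C\c4ccccc4)c4ccccc43)nn2)[C@H](OC(C)=O)[C@@H](OC(C)=O)[C@@H]1OC(C)=O` is the single member of the set with a number: in this assay compound 3 gives 33300 nM. Among the compounds with values here, it is thus the only value shown, while the other two entries sit at the limit of > 200000 nM in this assay, at which 2 of the 3 values shown sit, so no step between measured compounds can be read from these data.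

Compound 4 `CC(=O)OC[C@H]1O[C@@H](n2cc(CN3C(=O)/C(=C\c4ccc(C)cc4)c4ccccc43)nn2)[C@H](OC(C)=O)[C@@H](OC(C)=O)[C@@H]1OC(C)=O` differs from compound 3 in one place: methyl in place of hydrogen on an aromatic carbon, para to a large group, which read one bond further out is phenyl to 4-methylphenyl. Within the data shown here, nothing among the measured compounds tells how this assay responds to a change of this kind, and a single methyl on an aromatic ring is a small alteration.

The step from compound 3 to compound 4 is therefore expected to be a 1.2-fold lower number from compound 3 to compound 4 (0.08 log units; within the scatter), no larger than the usual scatter and in no firm direction. Compound 4 is expected to give about 28000 nM in this assay, within a range from 9000 nM to 90000 nM.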

Compound 4, half-maximal inhibitory concentration: > 100000 nM
Compound 4: a limit, no number (the forecaster's own chance of this, stated with the estimate: 15%); middle value at least 3.5-fold (0.55 log units) from the limit.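

With methyl in place of hydrogen on an aromatic carbon, para to a large group, this assay gives its first readable step between measured compounds, an at least 3.0-fold higher number from compound 3 to compound 4 (0.47 log units; beyond the scatter), so this position responds to even this one added carbon, with the higher number standing for weaker inhibition. Compound 4 gives a limit and not a number: the limit of > 100000 nM in this assay, at which 1 of the 4 values shown sits. The earlier compounds could not show this, as compound 3 was the only one with a number and no step could be read among them, and the other limits leave compound 3 as the sole number still: the limit of > 200000 nM in this assay, at which 2 of the 4 values shown sit.

The compounds shown leave open how much further the number of compound 4 lies from that of compound 3, and whether the response belongs to methyl alone or would also appear with a chlorine, a methoxy group or an amine at the same place. They also leave open whether a methyl on an aromatic carbon elsewhere in this ring would give a similar step, and all other steps among these compounds cannot be read.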